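Swapping the group on the sulfonyl sulfur of compound 1

The compounds below may be only part of what the source reports. "The series", "measured", "known", "first", "only" and "open" are said of these compounds alone.

Measured in a functional assay on DU-145 cells (Homo sapiens) for inhibition, read by trypan blue exclusion, with a stated time of 72 h; a lower number here means a stronger inhibitor, a higher number a weaker inhibitor:
- Compound 1 `Cn1c(=O)c(S(=O)(=O)c2ccc(Cl)cc2Cl)cc2cnc(Nc3ccc4[nH]ccc4c3)nc21`: 1000 nM
- Compound 2 `Cn1c(=O)c(S(=O)(=O)c2ccc(F)cc2)cc2cnc(Nc3ccc4occc4c3)nc21`: 5000 nM

Compound 1 has the lower of the two numbers, which makes it the stronger inhibitor so far. Compound 3 `Cn1c(=O)c(S(=O)(=O)Cc2ccc(F)cc2)cc2cnc(Nc3ccc4[nH]ccc4c3)nc21`, not yet measured, has 4-fluorobenzyl in place of 2,4-dichlorophenyl on a sulfonyl sulfur. Among the compounds with values here, no measured pair shows this change alone, so any expectation is loose. Only a small shift toward a lower number is expected in this assay, and the estimated change is a 1.7-fold lower number from compound 1 to compound 3 (0.22 log units; within the scatter). For compound 3 the expected value is 600 nM, with an estimated range from 80 nM to 4000 nM.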

Compound 3, half-maximal inhibitory concentration: 30000 nM
Compound 3: the middle estimate sits 50-fold (1.70 log units) below what was measured, and the stated range ends below it.
By their numbers in this assay, from the lowest: compound 1; then compound 2; then compound 3.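

In this assay, the group on the sulfonyl sulfur clearly matters: 4-fluorobenzyl in place of 2,4-dichlorophenyl gives a 30-fold higher number from compound 1 to compound 3 (1.48 log units; beyond the scatter). The two groups have the same number of heavy atoms and one aromatic ring each, so these counts do not predict the outcome. Nothing measured here explains the loss of potency.

On these data alone, the change alters both the link from ring to sulfur and the halogens on the ring, so their separate contributions remain open. A 2,4-dichlorobenzyl group would keep the halogens of compound 1 while adding the carbon link of compound 3.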